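From an Amino Group to a 4-Methoxyphenyl Group

A few compounds are considered here, and "the series" means these few. Any claim that something is new, unique, unknown or untested is made for them only; others in the source may bear on it.

Compound 1 `Cc1noc(C)c1S(=O)(=O)N1CCC(N2CCC(C)CC2)CC1`: > 5000 nM (a limit)
Compound 2 `CC1CCN(C2CCN(S(=O)(=O)c3cccc(N)c3)CC2)CC1`: 3400 nM
Compound 3 `CC1CCN(C2CCN(S(=O)(=O)c3ccccc3Br)CC2)CC1`: 3 nM

In a functional assay on DLD-1 cells (Homo sapiens) for antiproliferative activity, read by CellTiter-Glo, with a stated time of 72 h (on this read-out lower numbers stand for stronger inhibition and higher numbers for weaker inhibition), compound 1 gives > 5000 nM, which is a limit and not a number. Of the two actual numbers, compound 2 has the higher. The gap between them is a 1100-fold lower number from compound 2 to compound 3 (3.05 log units; beyond the scatter).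

Compound 4 `COc1ccc(-c2cccc(S(=O)(=O)N3CCC(N4CCC(C)CC4)CC3)c2)cc1` differs from compound 2 as follows: 4-methoxyphenyl in place of amino on an aromatic carbon. In words, 4-methoxyphenyl stands in place of amino on an aromatic carbon, meta to a large group.

Going by the values given here, no measured step makes this exact change. The closest evidence comes from swapping the whole group on the sulfonyl sulfur. One such swap is an at least 1.4-fold lower number from compound 1 to compound 2 (0.16 log units; that floor lies within the scatter), whose floor lies within the scatter, while another is an at least 1600-fold lower number from compound 1 to compound 3 (3.22 log units; beyond the scatter), which is large. Such swaps can therefore do little or a great deal, so the forecast is loose. With compound 2 at 3400 nM, a moderate fall in this assay is expected, though none beyond the scatter remains possible. The expected change is an 8.5-fold lower number from compound 2 to compound 4 (0.93 log units; beyond the scatter). Compound 4 is estimated at 400 nM, with an expected range from 20 nM to 5000 nM.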

Compound 4, half-maximal inhibitory concentration: 23 nM
Compound 4: the middle estimate sits 17-fold (1.24 log units) above what was measured, within the range that was stated.
By their numbers in this assay, from the lowest: compound 3; then compound 4; then compound 2. At a limit, above all of these: compound 1.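

Earlier steps replaced the whole group on the sulfonyl sulfur, whereas this change keeps the six-membered aromatic ring of carbon only and alters one aromatic carbon, meta to a large group; in this assay the result is a 150-fold lower number from compound 2 to compound 4 (2.17 log units; beyond the scatter). This position therefore accepts a much larger group than amino, one that brings a second aromatic ring, and a low number here does not need the hydrogen-bond donor that amino carries. Nothing measured here says why the number falls so far.

The compounds shown do not separate the contribution of the added ring from that of its methoxy group. A plain phenyl at the same aromatic carbon would test the ring alone, and a carboxylic acid on that ring would test whether a charged group is accepted there.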